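A few compounds are considered here, and "the series" means these few. Any claim that something is new, unique, unknown or untested is made for them only; others in the source may bear on it.

Measured so far:
Compound 1 `CC1=NC(C)=C(C(=O)OCCCN2C(=O)c3ccccc3S2(=O)=O)C(c2cccc([N+](=O)[O-])c2)/C1=C(\O)OC(C)C` gives 1 nM
Compound 2 `COCCO/C(O)=C1\C(C)=NC(C)=C(C(=O)OCCCN2C(=O)c3ccccc3S2(=O)=O)C1c1cccc([N+](=O)[O-])c1` gives 6.8 nM

Both compounds were tested in a functional assay (aorta) with Oryctolagus cuniculus as the target; a lower number here means a stronger inhibitor, a higher number a weaker inhibitor. For the measured compounds named here, compound 1 gives the lowest of the two numbers; the only other number comes from compound 2, and the step of a 6.8-fold higher number from compound 1 to compound 2 (0.83 log units; beyond the scatter) is the single change in the set, a swap of one ester group for another on the shared core.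

Compound 3 `CC1=NC(C)=C(C(=O)OCCCN2C(=O)c3ccccc3S2(=O)=O)C(c2ccccc2[N+](=O)[O-])/C1=C(\O)OC(C)C` has not yet been measured. It differs from compound 1 in a different place: 2-nitrophenyl in place of 3-nitrophenyl on a saturated ring carbon. The two compounds are built from the same atoms, joined differently; the nitro group sits elsewhere on the aromatic ring.

Going by the values given here, no measured step touches this ring. Among the compounds with values here, the one step that exists, from compound 1 to compound 2, concerns the ester and says nothing about where the nitro group sits. With no guide from the data, the expected step is a modest one, a 2.0-fold higher number from compound 1 to compound 3 (0.30 log units; within the scatter), possibly no more than the scatter. Compound 3 is therefore expected to give about 2 nM in this assay, with a range from 0.4 nM to 10 nM.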

Compound 3, half-maximal inhibitory concentration: 1.2 nM
Compound 3: the middle estimate sits 1.7-fold (0.22 log units) above what was measured, and the stated range covers the measured number.
By their numbers in this assay, from the lowest: compounds 1 and 3 (each within the scatter of the next); then compound 2.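

In this assay, the step from 3-nitrophenyl to 2-nitrophenyl on the saturated ring carbon is a 1.2-fold higher number from compound 1 to compound 3 (0.08 log units; within the scatter), so the two nitrophenyl compounds cannot be told apart by this measurement. For the compounds shown here, this gives the first reading at this position, and with either of these two groups on that carbon, the number stays in the lowest group of the set. By contrast, the ester swap, a 6.8-fold higher number from compound 1 to compound 2 (0.83 log units; beyond the scatter), remains the only step here that lies beyond the scatter, so among the changes shown, the ester change is the one that registers in this assay.

No measured information accounts for why the two nitrophenyl compounds read alike.

The compounds shown leave open whether the nitro group is needed at all, since a plain phenyl ring, or a ring carrying a chlorine atom or a nitrile instead, could read quite differently. Equally open, as far as these compounds go, is whether 2-nitrophenyl and 3-nitrophenyl would still read alike on the core of compound 2, which carries the 2-methoxyethyl group in place of isopropyl.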